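A Methyl on the Aromatic Nitrogen of Compound 3

The source may report more compounds than this note shows. Statements on the series, on what has been measured and on what is new or still open speak of the compounds shown alone.

Of the compounds shown here, three have been measured so far in a functional assay on KB403 cells (Homo sapiens) for cytotoxicity, read by MTT assay, with stated times of 6 h and 48 h; on this read-out lower numbers stand for stronger inhibition and higher numbers for weaker inhibition. Compound 1 `Cn1c(/C=C/C(=O)c2ccc(O)cc2O)cc(Br)c1Br` gives 12000 nM. Compound 2 `COc1ccc(OC)c(C(=O)/C=C/c2cc(Br)c(Br)[nH]2)c1` gives >= 100000 nM, which is a limit of the assay and not a number. Compound 3 `O=c1cc(-c2cc(Br)c(Br)[nH]2)oc2ccccc12` gives 1280 nM, the lowest number of the set, and the gap to compound 1, its nearest neighbour among the numbers, lies beyond the usual scatter.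

Compound 4 `Cn1c(-c2cc(=O)c3ccccc3o2)cc(Br)c1Br` has not yet been measured. It differs from compound 3 in one place: methyl in place of hydrogen on an aromatic nitrogen. Among the compounds with values here, no measured pair shows this change on its own. Compound 1 carries a methyl there and compound 2 does not, but those two also differ elsewhere, so they cannot isolate it.

The change adds only one heavy atom, so a modest move towards a higher number is expected in this assay, though a result within the scatter would be no surprise. Within the data shown here, the one measured compound with this methyl, compound 1 at 12000 nM, leans the expectation in that direction. The expected size is a 2.0-fold higher number from compound 3 to compound 4 (0.29 log units; within the scatter). For compound 4 the estimate is 2500 nM, with an expected range from 600 nM to 12000 nM.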

Compound 4, half-maximal inhibitory concentration: 670 nM
Compound 4: the middle estimate sits 3.7-fold (0.57 log units) above what was measured, within the range that was stated.
By their numbers in this assay, from the lowest: compounds 4 and 3 (each within the scatter of the next); then compound 1. At a limit, above all of these: compound 2.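

Within the data shown here, for the first time, a single pair isolates methyl in place of hydrogen on an aromatic nitrogen: in this assay the change gives a 1.9-fold lower number from compound 3 to compound 4 (0.28 log units; within the scatter) and so leaves the number within the usual spread of repeated measurements. On this core, then, the hydrogen on this nitrogen can be replaced by a methyl without a measurable loss, even though the nitrogen lies next to the ring atom that bears a bromo group and next to the ring atom that bears a large group. Nothing measured here offers a cause for this outcome, and a step this small calls for none.

The compounds shown carry only hydrogen or methyl on this nitrogen, so it remains open whether the position would also accept something bigger, such as an ethyl group, a longer chain or a chain ending in an amine. Among these compounds, it also remains open whether the methyl would have the same small effect on the core of compound 1, as no pair on that core isolates this change.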